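The source may hold more compounds than are shown below. What is called first, only, known or untested is meant among the compounds shown, and "the series" means these compounds.

Three compounds have so far been run through an ADME assay on H9c2 cells (Rattus norvegicus) for cytotoxicity, read by MTT assay, with a stated time of 48 h; a lower number here means a stronger inhibitor, a higher number a weaker inhibitor. Compound 1 `COc1ccc(NC(=S)OCCNC(=O)C(C)(C)Oc2ccc(Cl)cc2)cc1` gives 747000 nM in this assay. Compound 3 `Cc1ccc(NC(=S)OCCNC(=O)C(C)(C)Oc2ccc(Cl)cc2)cc1` gives 771000 nM; it differs from compound 1 only by methyl in place of methoxy on an aromatic carbon. The resulting step of a 1.0-fold higher number from compound 1 to compound 3 (0.01 log units; within the scatter) leaves the read-out essentially where it stood. Compound 2 `COc1ccc(NC(=S)OCCNC(=O)c2cccnc2)cc1` rests on a different core, and the difference between the core of compound 1 and the core of compound 2 is not broken down here. In this assay compound 2 gives 695000 nM, a number that lies within the scatter of both compound 1 and compound 3, so no ordering among the three can be claimed.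

Compound 4 `Cc1ccc(NC(=S)OCCNC(=O)c2cccnc2)cc1` has not yet been measured. It is related to compound 2 by methyl in place of methoxy on an aromatic carbon, the same change that separates compound 3 from compound 1, at the same place on the ring. Since that change produced the step of a 1.0-fold higher number from compound 1 to compound 3 (0.01 log units; within the scatter), a step of similar size is expected on the second core, namely a 1.0-fold higher number from compound 2 to compound 4 (0.00 log units; within the scatter). Resting on compound 2 at 695000 nM, compound 4 is estimated at 700000 nM. The measurement for compound 4 is expected to fall between 450000 nM and 1100000 nM. Whether this expectation holds will be seen once the number for compound 4 is in hand.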

Compound 4, half-maximal inhibitory concentration: 726000 nM
Estimate against measurement, compound 4: 1.0-fold (0.02 log units) below; the measured number falls inside the stated range.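

Methyl in place of methoxy on an aromatic carbon, para to a large group, was now read on the second core, and in this assay it gives a 1.0-fold higher number from compound 2 to compound 4 (0.02 log units; within the scatter). Set beside the earlier step, this shows that the change carried over from the core of compound 1 to the core of compound 2 without any difference that can be read, and that neither core registers the exchange of these two groups beyond the scatter: the same change on two cores in this assay, a 1.0-fold higher number (0.01 log units; within the scatter) from compound 1 to compound 3 and a 1.0-fold higher number (0.02 log units; within the scatter) from compound 2 to compound 4, 1.0-fold (0.01 log units) apart, within the scatter of two such steps. It does not show that steps in this series add up in general, since the agreement rests on two cores, one place on the ring and one pair of groups, and two steps that both lie within the scatter cannot tell whether a step of real size would carry over in the same way.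

The compounds shown leave open whether an amine, a carboxylic acid or a longer chain at that same place on the ring would move the number beyond the scatter at all. They also leave open whether the agreement between the two cores would still hold for such a group, or on a third core.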